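The source may hold more compounds than are shown below. What is called first, only, known or untested is meant among the compounds shown, and "the series" means these compounds.

The compounds measured so far:

Compound 1, `O=C(CN(c1ncnc2c1ncn2C1CCCCO1)C1CC1)N[C@@H](CCC(=O)OCc1ccccc1)C(=O)OCc1ccccc1` — 32.6%
Compound 2, `O=C(OCc1ccccc1)[C@@H]1CCCN1C(=O)CN(c1nc(Cl)nc2[nH]cnc12)C1CC1` — 33.2%
Compound 3, `N=C(N)NCCC[C@H](NC(=O)CN(c1nc(Cl)nc2[nH]cnc12)C1CC1)C(=O)OCc1ccccc1` — 23.2%

All three numbers come from a functional assay on the whole organism (Tail, strain ICR) with Mus musculus as the target, in the tail flick test, with a stated time of 30 min, at a dose of 25 umol/kg by the oral route; on this read-out lower numbers stand for a weaker effect and higher numbers for a stronger effect at the one dose given. On the bare numbers, compound 1 stands second highest of the three, with compound 1 giving 32.6%. Its nearest neighbour is compound 2, whose number lies only slightly higher, a gap that falls within the usual scatter of this assay. The furthest is compound 3, whose number lies lower, yet that gap too falls within the scatter. Within the data shown here, the three compounds therefore cannot be told apart on these numbers, and no step between any pair has been worked out.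

The compound not yet measured is compound 4, `CC[C@H](C)[C@H](NC(=O)CN(c1ncnc2c1ncn2C1CCCCO1)C1CC1)C(=O)OCc1ccccc1`. It differs from compound 1 in one place:

sec-butyl in place of 2-(benzyloxycarbonyl)ethyl on a saturated chain carbon bound to an amide-type nitrogen and a carbonyl carbon

Among the measured compounds shown here, since no step between measured compounds is available to calibrate this change, and the three measured numbers sit close together, the expectation for compound 4 rests on the spread of those numbers alone. In this assay the step is expected to be small, with no direction that stands out beyond the scatter. Compound 4 is estimated to give 30%, with a range from 15% to 45%, which would amount to an expected step of a number 2.6 percentage points lower from compound 1 to compound 4 (within the scatter).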

Compound 4, a percentage reported as activity, at one dose (the size of the read-out at that dose, not a potency): 25.6%
Beside the measured number, compound 4's estimate is 4.4 percentage points above it, within the range that was stated.
By their numbers in this assay, from the lowest: compounds 3, 4, 1 and 2 (each within the scatter of the next).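

Among these compounds, compound 4 gives the first step at this position that can be read in this assay: on a saturated chain carbon bound to an amide-type nitrogen and a carbonyl carbon, sec-butyl in place of 2-(benzyloxycarbonyl)ethyl gives a number 7 percentage points lower from compound 1 to compound 4 (within the scatter). The change is a large one in structure, since the six-membered aromatic ring of carbon only, the double bond outside aromatic rings and the hydrogen-bond acceptors of the leaving group all go, and a smaller group with no ring and a defined stereocentre enters, yet the read-out at the one dose given does not separate the two compounds. No measurement is available that would explain this result.

Going by these compounds, it remains open whether a carboxylic acid, an amine or a longer alkyl chain on this carbon would give a step beyond the scatter. On these data alone, it also remains open whether the same exchange would give a similarly small step on the core of compound 2, or whether compound 1 and compound 4 would stay together at other doses and times.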